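The source may hold more compounds than are shown below. What is called first, only, known or untested is meant among the compounds shown, and "the series" means these compounds.

Of the compounds shown here, three built on one shared core have been tested in a functional assay on NCI-H1975 cells (Homo sapiens) for inhibition, read by MTT assay, with a stated time of 72 h; a higher number here means a weaker inhibitor, a lower number a stronger inhibitor. Compound 1 `C=CC(=O)Nc1cccc(NC(=O)CSc2nc(Nc3cccc(Br)c3)c3ccccc3n2)c1` gives 12100 nM in this assay. Compound 2 `C=CC(=O)Nc1cccc(NC(=O)CSc2nc(Nc3ccc(Cl)cc3)c3ccccc3n2)c1` gives 7580 nM in this assay. Compound 3 `C=CC(=O)Nc1cccc(NC(=O)CSc2nc(Nc3ccc(CC)cc3)c3ccccc3n2)c1` gives 8270 nM in this assay. Of these three numbers, that of compound 3 is the second highest, but the spread is small: a 1.1-fold higher number from compound 2 to compound 3 (0.04 log units; within the scatter), and a 1.5-fold lower number from compound 1 to compound 3 (0.17 log units; within the scatter). Both steps are within the scatter, so the three compounds cannot be ranked against one another.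

Compound 4 `C=CC(=O)Nc1cccc(NC(=O)CSc2nc(Nc3cc(OC)c(OC)c(OC)c3)c3ccccc3n2)c1` differs from compound 3 in one place: 3,4,5-trimethoxyphenyl in place of 4-ethylphenyl on a nitrogen on an aromatic ring. The measured steps that bear on this change are the ones that also swap the group on this nitrogen: a 1.6-fold lower number from compound 1 to compound 2 (0.20 log units; within the scatter), a 1.5-fold lower number from compound 1 to compound 3 (0.17 log units; within the scatter) and a 1.1-fold higher number from compound 2 to compound 3 (0.04 log units; within the scatter). None of them moved the number beyond the scatter, although none of them introduced methoxy groups, so the new change is only partly covered. On this evidence, no step beyond the scatter is expected for compound 4 in this assay; the expected step is a 1.0-fold higher number from compound 3 to compound 4 (0.01 log units; within the scatter). Compound 4 is therefore estimated to give about 8500 nM in this assay, with a likely range from 3000 nM to 25000 nM.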

Compound 4, half-maximal inhibitory concentration: > 50000 nM
Compound 4 was reported as a limit (the forecaster's own chance of this, stated with the estimate: 10%); middle value at least 5.8-fold (0.76 log units) from the limit.
By their numbers in this assay, from the lowest: compounds 2, 3 and 1 (each within the scatter of the next). At a limit, above all of these: compound 4.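

In this assay compound 4 is reported only as a limit and not as a number: the limit of > 50000 nM in this assay, at which 1 of the 4 values shown sits. The earlier swaps among 3-bromophenyl, 4-chlorophenyl and 4-ethylphenyl on this nitrogen all stayed within the scatter, so those compounds gave no sign that the group here could matter, whereas 3,4,5-trimethoxyphenyl gives an at least 6.0-fold higher number from compound 3 to compound 4 (0.78 log units; beyond the scatter) and an at least 6.5-fold higher number from compound 2 to compound 4 (0.81 log units; beyond the scatter) and an at least 4.1-fold higher number from compound 1 to compound 4 (0.61 log units; beyond the scatter), each beyond the scatter. Among these four compounds, then, this place on the nitrogen does not accept every substituted phenyl group alike, and the one group that stands apart is also the largest by heavy atoms and the only one with hydrogen-bond acceptors.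

The compounds shown do not tell whether all three methoxy groups are needed for this loss, since a phenyl ring with a single methoxy group, or with a small amine in its place, would be the step that separates these possibilities. As far as these compounds go, the true size of the step also stays open as long as compound 4 is known only as a limit.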